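A few compounds are considered here, and "the series" means these few. Any claim that something is new, unique, unknown or untested is made for them only; others in the source may bear on it.

Among the compounds with values here, in a functional assay on KB cells (Homo sapiens) for inhibition (a higher number here means a weaker inhibitor, a lower number a stronger inhibitor), compound 1 `N/C(=N\O)c1cn([C@@H]2O[C@H](CO)[C@@H](O)[C@H]2O)c2nnnc(N)c12` gives 1500 nM, the higher and therefore weaker of the two numbers measured so far. Its close relative, compound 2 `NC(=O)c1cn([C@@H]2O[C@H](CO)[C@@H](O)[C@H]2O)c2nnnc(N)c12`, gives 80 nM. Compound 3 `NC(=S)c1cn([C@@H]2O[C@H](CO)[C@@H](O)[C@H]2O)c2nnnc(N)c12` has not yet been measured. It differs from compound 1 in one place, on an aromatic carbon of a five-membered aromatic ring with 1 nitrogen: a group of 3 heavy atoms (1 carbon, 1 nitrogen, 1 sulfur; no ring) in place of a group of 4 heavy atoms (1 carbon, 2 nitrogen, 1 oxygen; no ring), on an aromatic carbon. Within the data shown here, only one measured step bears on this change, and it is large: a 19-fold lower number from compound 1 to compound 2 (1.27 log units; beyond the scatter). That step removed the same group from compound 1 and also put in a group of 3 heavy atoms. The groups in compound 2 and compound 3 differ in a single atom, oxygen against sulfur. Among the measured compounds shown here, nothing measured so far shows what that exchange does, so one step is thin evidence and the range must stay wide. A clear move towards a lower number is still expected, and its estimated size is a 10-fold lower number from compound 1 to compound 3 (1.00 log units; beyond the scatter). For compound 3 the expected value is 150 nM, with a likely range from 30 nM to 800 nM.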

Compound 3, half-maximal inhibitory concentration: 2000 nM
Compound 3: the middle estimate sits 13-fold (1.12 log units) below what was measured, and the stated range ends below it.
By their numbers in this assay, from the lowest: compound 2; then compounds 1 and 3 (each within the scatter of the next).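

In this assay, the step of a 25-fold higher number from compound 2 to compound 3 (1.40 log units; beyond the scatter) shows that this position is sensitive to a single atom: exchanging oxygen for sulfur leaves the heavy-atom count of the group unchanged, yet it removes the advantage seen with compound 2. The step of a 1.3-fold higher number from compound 1 to compound 3 (0.12 log units; within the scatter) lies within the scatter, so compound 1 and compound 3 cannot be told apart here despite their different groups, and a group of the smaller size is therefore not enough on its own to give a low number. Nothing measured here explains why oxygen and sulfur differ so sharply at this position.

These compounds leave open whether the low number belongs only to the group in compound 2, or whether other groups on this aromatic carbon, such as a carboxylic acid, a nitrile or a methyl ester, could match it. With only one oxygen-to-sulfur pair shown, it also remains open whether this exchange would have a similar effect elsewhere on the core or on a compound with a different core.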